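A few compounds are considered here, and "the series" means these few. Any claim that something is new, unique, unknown or untested is made for them only; others in the source may bear on it.

In a functional assay on HOS cells (Homo sapiens) for inhibition, read by MTT assay, with a stated time of 72 h (on this read-out higher numbers stand for weaker inhibition and lower numbers for stronger inhibition), three compounds sharing one core have been measured: compound 1 (`O=C(CCC(=O)OCCCCCCSc1ccc([N+](=O)[O-])c2nonc12)Nc1ccccc1`) gives 2120 nM, compound 2 (`O=C(CCC(=O)OCCCCCCSc1ccc([N+](=O)[O-])c2nonc12)Nc1ccc(C(F)(F)F)cc1`) gives 3200 nM, and compound 3 (`COc1ccc(NC(=O)CCC(=O)OCCCCCCSc2ccc([N+](=O)[O-])c3nonc23)cc1OC`) gives 1390 nM. Compound 3 cannot be separated from compound 1, with a 1.5-fold lower number from compound 1 to compound 3 (0.18 log units; within the scatter). It stands apart only from compound 2, with a 2.3-fold lower number from compound 2 to compound 3 (0.36 log units; beyond the scatter), and a 1.5-fold higher number from compound 1 to compound 2 (0.18 log units; within the scatter) also stays small. Compound 4 (`CN(C)CCCNC(=O)CCC(=O)OCCCCCCSc1ccc([N+](=O)[O-])c2nonc12`) now carries 3-(dimethylamino)propyl in place of 3,4-dimethoxyphenyl on an amide-type nitrogen. Each measured step exchanges one aromatic group on that nitrogen for another, and none replaces the ring with a chain, so they offer only loose guidance. Within the data shown here, since the largest of them is the modest 2.3-fold lower number from compound 2 to compound 3 (0.36 log units; beyond the scatter), no step clearly beyond the scatter is expected in this assay, with only a slight lean towards a higher number. The estimated step is a 1.4-fold higher number from compound 3 to compound 4 (0.16 log units; within the scatter). Compound 4 is expected at 2000 nM, with an estimated range from 700 nM to 5500 nM.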

Compound 4, half-maximal inhibitory concentration: 1850 nM
Beside the measured number, compound 4's estimate is 1.1-fold (0.03 log units) above it, and the stated range covers the measured number.
By their numbers in this assay, from the lowest: compounds 3, 4, 1 and 2 (each within the scatter of the next, the first and the last beyond it).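

In this assay, the amide-type nitrogen accepts a chain with no ring as well as it accepts the aromatic groups: 3-(dimethylamino)propyl gives a 1.3-fold higher number from compound 3 to compound 4 (0.12 log units; within the scatter), a 1.7-fold lower number from compound 2 to compound 4 (0.24 log units; within the scatter) and a 1.1-fold lower number from compound 1 to compound 4 (0.06 log units; within the scatter), all within the scatter. The earlier compounds shown here only exchanged one aromatic group for another, whereas compound 4 shows that an aromatic ring on this nitrogen is not required for a number of this size in this assay. Nothing available bears on why the number holds across this change.

From the compounds shown here alone, it remains open whether a shorter or longer chain, a chain ending in a carboxylic acid, or a morpholine in place of the dimethylamino group would also stay within the scatter. Going by these compounds, it is equally open whether a methyl group could replace the amide hydrogen.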